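Nitro for trifluoromethyl on the aryl arm

The source may report more compounds than this note shows. Statements on the series, on what has been measured and on what is new or still open speak of the compounds shown alone.

Measured so far in a functional assay on PC-3 cells (Homo sapiens) for cytotoxicity, read by MTT assay, with a stated time of 72 h; on this read-out higher numbers stand for weaker inhibition and lower numbers for stronger inhibition:
compound 1 `COc1ccc(/C=C/C(=O)/C=C/C2=C(C)CCCC2(C)C)cc1O` gives 37400 nM
compound 2 `CC1=C(/C=C/C(=O)/C=C/c2cccc(C(F)(F)F)c2)C(C)(C)CCC1` gives 7700 nM
compound 3 `CC1=C(/C=C/C(=O)/C=C/c2cc(C(F)(F)F)cc(C(F)(F)F)c2)C(C)(C)CCC1` gives 7200 nM

Compound 2 stands second highest of the three numbers. Its nearest neighbour is compound 3: a 1.1-fold lower number from compound 2 to compound 3 (0.03 log units; within the scatter), a change within the scatter, so the two are not ordered. Going by the values given here, compound 1 is the furthest, with the highest number of the three, and that gap lies beyond the scatter; no single-point step connects compound 1 to compound 2, so only the two values themselves are known.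

Compound 4 `CC1=C(/C=C/C(=O)/C=C/c2cccc([N+](=O)[O-])c2)C(C)(C)CCC1` differs from compound 2 by nitro in place of trifluoromethyl on an aromatic carbon. Among the compounds with values here, no measured step swaps one group on this ring for another. Within the data shown here, the only step that bears on it is the one from compound 2 to compound 3, where a further trifluoromethyl entered the same ring and the number barely moved. On that basis a change of similar size, within the scatter and with no clear direction, is expected in this assay; a slight lean to a higher number is allowed for, since nothing here shows that the nitro group reaches the level of compound 2.

Compound 4 is therefore estimated at 9500 nM, with a range of 3500 nM to 26000 nM, which means an expected step of a 1.2-fold higher number from compound 2 to compound 4 (0.09 log units; within the scatter).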

Compound 4, half-maximal inhibitory concentration: 10000 nM
Estimate against measurement, compound 4: 1.1-fold (0.02 log units) below; low and high end bracket the measured number.
By their numbers in this assay, from the lowest: compounds 3, 2 and 4 (each within the scatter of the next); then compound 1.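

In this assay, replacing the group itself on this aromatic carbon, meta to a large group, gives a 1.3-fold higher number from compound 2 to compound 4 (0.11 log units; within the scatter), so compound 2 and compound 4 are not ordered. The earlier step, a 1.1-fold lower number from compound 2 to compound 3 (0.03 log units; within the scatter), showed only that a further trifluoromethyl could enter the ring without a change beyond the scatter; it did not test any other group at the existing place. The new step adds that trifluoromethyl can give way to nitro, a group with hydrogen-bond acceptors replacing one without, and the number still stays within the scatter, though no measured property is available to account for this flat result.

Still open, from the compounds shown here alone, is whether any group on this aromatic carbon moves the number beyond the scatter, since both changes read so far stay within it; an amine, a carboxylic acid or a methoxy group would put that to the test. Going by these compounds, it is also open whether the flat result holds with plain hydrogen at this place, or whether the ring needs a substituent here at all.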